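A few compounds are considered here, and "the series" means these few. Any claim that something is new, unique, unknown or untested is made for them only; others in the source may bear on it.

Measured so far:
compound 1 `COc1cc(/C=C/c2nc(Nc3ccc(C(C)C)cc3)c3sccc3n2)cc(OC)c1OC` — in a functional assay on L02 cells (Homo sapiens) for inhibition, read by Griess assay, with stated times of 1 h and 24 h (a higher number here means a weaker inhibitor, a lower number a stronger inhibitor), compound 1 gives 370000 nM.
compound 2 `COc1cc(/C=C/c2nc(Nc3ccc(O)cc3)c3sccc3n2)cc(OC)c1OC` — in this assay compound 2 gives only a limit, > 1000000 nM.

Compound 2 thus stands at the limit of > 1000000 nM in this assay, at which 1 of the 2 values shown sits, with no number of its own. Compound 3 `COc1cc(/C=C/c2nc(NCc3ccccc3)c3sccc3n2)cc(OC)c1OC` differs from compound 2 by benzyl in place of 4-hydroxyphenyl on a nitrogen on an aromatic ring. Within the data shown here, the one measured step, an at least 2.7-fold higher number from compound 1 to compound 2 (0.43 log units; beyond the scatter), concerns a different change and bears only loosely here, though compound 3, like compound 1, carries no hydroxy. A step back toward compound 1 is expected, the estimated step being an at least 1.6-fold lower number from compound 2 to compound 3 (0.22 log units; that floor lies within the scatter). For compound 3 the expected value in this assay is 600000 nM, within 250000 nM to 1500000 nM, with a fair chance that only a limit is again reported.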

Compound 3, half-maximal inhibitory concentration: > 1000000 nM
Compound 3 gave a limit, no number; the forecaster's own chance of this, stated with the estimate: 40%; at least 1.6-fold (0.22 log units) between middle value and limit.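

Putting benzyl in place of 4-isopropylphenyl on the nitrogen gives, in this assay, an at least 2.7-fold higher number from compound 1 to compound 3 (0.43 log units; beyond the scatter), so a group without hydroxy also loses the readable value. Compound 1 remains the only one of the three with a number, and the weak end of the series is not tied to hydroxy alone: the limit of > 1000000 nM in this assay, at which 2 of the 3 values shown sit.

The step between compound 2 and compound 3 cannot be read, as both values are limits. From the compounds shown here alone, whether the isopropyl group or the phenyl ring sitting directly on the nitrogen underlies the value of compound 1 stays open, and a 4-tert-butylphenyl or plain phenyl group on that nitrogen would bear on this.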